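The compounds below may be only part of what the source reports. "The series", "measured", "known", "first", "only" and "open" are said of these compounds alone.

Measured so far in an assay on isolated protein for inhibition of Amine oxidase [flavin-containing] B (Homo sapiens), read by Amplex Red; a lower number here means a stronger inhibitor, a higher number a weaker inhibitor:
compound 1, `COc1ccc(OC/C(F)=C\CN)cc1`: 310 nM
compound 2, `NC/C=C(/F)COc1ccc(Oc2ccccc2)cc1`: 450 nM
compound 3, `NC/C=C(/F)COc1cccc(Cl)c1`: 30 nM

Compound 1 holds the second highest of the three numbers in this assay. Compound 2 sits nearest, a 1.5-fold higher number from compound 1 to compound 2 (0.16 log units; within the scatter). Compound 3 gives the lowest number, and its gap to compound 1 lies beyond the scatter.

Compound 4, `CC(C)(C)c1ccc(OC/C(F)=C\CN)cc1`, differs from compound 1 by tert-butyl in place of methoxy on an aromatic carbon. Among the measured compounds shown here, the only measured step that touches the same ring position, from compound 1 to compound 2, swapped methyl for phenyl on the oxygen and stayed within the scatter. For the measured compounds named here, no measured pair exchanges the oxygen-bearing group for a carbon-only group, so the data give no direction. A step within the scatter is therefore expected. Compound 4 is estimated at 300 nM, range 120 nM to 800 nM. The expected step is a 1.0-fold lower number from compound 1 to compound 4 (0.01 log units; within the scatter).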

Compound 4, half-maximal inhibitory concentration: 6400 nM
Beside the measured number, compound 4's estimate is 21-fold (1.33 log units) below it; measured number outside the range, above it.
By their numbers in this assay, from the lowest: compound 3; then compounds 1 and 2 (each within the scatter of the next); then compound 4.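

In this assay the step to tert-butyl in place of methoxy on an aromatic carbon is large: a 21-fold higher number from compound 1 to compound 4 (1.31 log units; beyond the scatter). This position therefore does not accept every group, which the earlier step of a 1.5-fold higher number from compound 1 to compound 2 (0.16 log units; within the scatter) could not show, since it changed only what sits on the oxygen and stayed within the scatter. Nothing measured here accounts for the loss.

Open, as far as these compounds go, is whether an ethyl group or a hydroxyl at this place would track tert-butyl or methoxy. Also open, from the compounds shown here alone, is how a chlorine at this same place would compare with compound 1.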